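Urea versus amide at the carbonyl of the shared core

This account rests on a few compounds, and the source may have more. Where it says the series, first, only, none or still open, it means among the compounds named here.

Measured so far in a functional assay on HCT-116 cells (Homo sapiens) for inhibition, read by sulforhodamine B assay, with a stated time of 48 h; a lower number here means a stronger inhibitor of growth, a higher number a weaker inhibitor of growth:
compound 1 `COc1cc(-c2nn(-c3cccc(NC(=O)Nc4cc(C(F)(F)F)cc(C(F)(F)F)c4)c3)cc2-c2ccncc2)ccc1Cl`, 1760 nM
compound 2 `COc1cc(-c2nn(-c3cccc(NC(=O)c4cccc(C(F)(F)F)c4)c3)cc2-c2ccncc2)ccc1Cl`, > 50000 nM
compound 3 `O=C(Nc1cccc(-n2cc(-c3ccncc3)c(-c3ccc(Cl)c(O)c3)n2)c1)Nc1ccc(Cl)c(Cl)c1`, 5730 nM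

Compound 2 is the only one of the three without a number: in this assay compound 2 gives > 50000 nM, which is a limit of the assay and not a measured value. It therefore sits at the weak end of the set, as noted in the limit of > 50000 nM in this assay, at which 1 of the 3 values shown sits. Compound 1 and compound 3, both of which carry a urea rather than an amide at the carbonyl, give numbers inside the range of the assay.

Compound 4 `COc1cc(-c2nn(-c3cccc(NC(=O)Nc4cccc(C(F)(F)F)c4)c3)cc2-c2ccncc2)ccc1Cl` is not yet measured. It differs from compound 2 at one place: (3-(trifluoromethyl)phenyl)amino in place of 3-(trifluoromethyl)phenyl on a carbonyl carbon. For the measured compounds named here, no measured pair shows this exact change, so the size of the step rests on the pattern that the two ureas, compound 1 and compound 3, give numbers while the amide, compound 2, gives only a limit. A step beyond the scatter, towards stronger growth inhibition, is expected from compound 2 to compound 4, namely an at least 10-fold lower number from compound 2 to compound 4 (1.00 log units; beyond the scatter). Compound 4 is estimated at 5000 nM, between 1500 nM and 20000 nM.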

Compound 4, concentration for total growth inhibition: 7170 nM
Beside the measured number, compound 4's estimate is 1.4-fold (0.16 log units) below it; the range from low to high includes it.
By their numbers in this assay, from the lowest: compound 1; then compounds 3 and 4 (each within the scatter of the next). At a limit, above all of these: compound 2.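

The change on the carbonyl carbon now has a matched pair in this assay: (3-(trifluoromethyl)phenyl)amino in place of 3-(trifluoromethyl)phenyl gives an at least 6.9-fold lower number from compound 2 to compound 4 (0.84 log units; beyond the scatter), a change that adds one nitrogen and one hydrogen-bond donor and turns the amide into a urea. The value of compound 2 is a limit of the assay, so this step gives only a minimum size and the full size of the change stays unknown: the limit of > 50000 nM in this assay, at which 1 of the 4 values shown sits.

Among the ureas, hydrogen in place of trifluoromethyl on an aromatic carbon gives a 4.1-fold higher number from compound 1 to compound 4 (0.61 log units; beyond the scatter), so the urea alone does not set the number and the substitution on its aromatic ring moves it as well.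

Still open, going by these compounds, is whether the step at the carbonyl carbon needs the hydrogen on the entering nitrogen, which a methyl group on that nitrogen, or an oxygen in its place as in a carbamate, would test. On these data alone, it is also open whether a second trifluoromethyl group on the aromatic ring of the amide would bring that compound inside the range of the assay, as it accompanies a lower number among the ureas.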